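The source may report more compounds than this note shows. Statements on the series, on what has been measured and on what is new or still open speak of the compounds shown alone.

The account starts from compound 1 `COc1c(N2CCN(CCC#N)C(C)C2)c(F)cc2c(=O)c(C(=O)O)cn(C3CC3)c12`, which in an ADME assay on Vero cells (Chlorocebus sabaeus) for cytotoxicity, read by MTT assay, with a stated time of 72 h (on this read-out lower numbers stand for higher toxicity in this test and higher numbers for lower toxicity in this test), gives 500 ug/mL. Two close relatives set the frame. In this assay compound 2 `COc1c(N2CCN(CC(C)=O)C(C)C2)c(F)cc2c(=O)c(C(=O)O)cn(C3CC3)c12` gives 500 ug/mL, and compound 3 `COc1c(N2CCN(CCC(C)=O)C(C)C2)c(F)cc2c(=O)c(C(=O)O)cn(C3CC3)c12` gives 9.84 ug/mL. Compound 1 stands level with compound 2, the two together holding the highest numbers of the three, while compound 3 lies furthest from it. The step of no change at the digits printed from compound 1 to compound 2 (within the scatter) shows that exchanging the group on the saturated chain carbon bound to the amine nitrogen left the number where it was. By contrast the step of a 51-fold lower number from compound 1 to compound 3 (1.71 log units; beyond the scatter) and the step of a 51-fold lower number from compound 2 to compound 3 (1.71 log units; beyond the scatter) show a large drop once an acetyl sits two bonds along the chain.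

Compound 4 `COc1c(N2CCN(CC/C(C)=N/NC(N)=O)C(C)C2)c(F)cc2c(=O)c(C(=O)O)cn(C3CC3)c12` differs from compound 1 by a group of 7 heavy atoms (3 carbon, 3 nitrogen, 1 oxygen; no ring) in place of a group of 2 heavy atoms (1 carbon, 1 nitrogen; no ring), on a saturated chain carbon, two bonds along the chain from an amine nitrogen in a ring. The step that bears most directly on this is a 51-fold lower number from compound 1 to compound 3 (1.71 log units; beyond the scatter), since it also replaced the cyano at that same place, and it was large. The group entering in compound 4 is neither cyano nor acetyl, so how far that lesson carries is uncertain; a lower number than compound 1 is expected, but with a wide spread. This corresponds to an expected step of an 8.3-fold lower number from compound 1 to compound 4 (0.92 log units; beyond the scatter). Compound 4 is therefore estimated to give 60 ug/mL in this assay, with a range from 9 ug/mL to 500 ug/mL.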

Compound 4, half-maximal cytotoxic concentration: 31.3 ug/mL
Compound 4: the middle estimate sits 1.9-fold (0.28 log units) above what was measured; measured number inside the range.
By their numbers in this assay, from the lowest: compound 3; then compound 4; then compounds 1 and 2 (each within the scatter of the next).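

In this assay, the group of 7 heavy atoms on a saturated chain carbon, two bonds along the chain from an amine nitrogen in a ring, gives a 16-fold lower number from compound 1 to compound 4 (1.20 log units; beyond the scatter), so a second replacement of the cyano at this place, after the acetyl of compound 3, also ends well under the level of compound 1. The same group set in place of the acetyl gives a 3.2-fold higher number from compound 3 to compound 4 (0.50 log units; beyond the scatter), a modest step, which shows that the number here is not settled by the loss of the cyano alone and that the two entering groups can be told apart. The step of a 16-fold lower number from compound 2 to compound 4 (1.20 log units; beyond the scatter) adds that compound 2 keeps the level of compound 1 while compound 4 does not.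

The compounds shown leave open whether an amine, a carboxylic acid or a longer chain at this place would stay near compound 3 or return towards compound 1. Nothing available accounts for the size or direction of any of these steps.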